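The source may report more compounds than this note shows. Statements on the series, on what has been measured and on what is new or still open speak of the compounds shown alone.

Compound 2, `COC(=O)c1ccc2ccc(C(=O)c3ccc(C(F)(F)F)cc3)c-2cc1`, is tested in an assay on cells for displacement of a labelled ligand from Orexin receptor type 2 (Homo sapiens), read by scintillation counting, with stated times of 10 min and 90 min, tested at 10 uM (a lower number here means less inhibition, a higher number more inhibition at the concentration tested (going by the name of the read-out)), where compound 2 gives -47.4%. That is the lowest of the three numbers at hand. For the measured compounds named here, compound 1, `COC(=O)c1ccc2ccc(C(=O)c3ccccc3)c-2cc1`, gives 28.9% in the same assay, and the step of a number 76.3 percentage points lower from compound 1 to compound 2 (beyond the scatter) is the only single-point change with a measured outcome. Going by the values given here, compound 3, `COC(=O)c1cccc2c(C(=O)c3ccccc3)cc(C(=O)c3ccc(C(Cl)(Cl)Cl)cc3)c-2c1`, gives 27%; the two values of compound 2 and compound 3 stand far apart, but no single-point step links them.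

Compound 4, `COC(=O)Cc1ccc2ccc(C(=O)c3ccc(C(F)(F)F)cc3)c-2cc1`, differs from compound 2 by (methoxycarbonyl)methyl in place of methoxycarbonyl on an aromatic carbon. Among the compounds with values here, no measured step involves this change: the one measured step concerns trifluoromethyl in place of hydrogen, not the ester-bearing group, so it gives no guidance on direction or size here. The expectation therefore rests on the value of compound 2 itself, with allowance for a negative reading drifting back toward the middle of the scale. The step from compound 2 to compound 4 is expected to be a number 12.4 percentage points higher from compound 2 to compound 4 (beyond the scatter). Compound 4 is estimated at -35%, within a range from -75% to 10%.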

Compound 4, a percentage reported as inhibition, at one concentration (the size of the read-out at that concentration, not a potency): 1%
Compound 4: the middle estimate sits 36 percentage points below what was measured, and the stated range covers the measured number.
By their numbers in this assay, from the lowest: compound 2; then compound 4; then compounds 3 and 1 (each within the scatter of the next).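

Where the group sits on an aromatic carbon of the seven-membered aromatic ring of carbon only, replacing methoxycarbonyl with (methoxycarbonyl)methyl gives in this assay a step of a number 48.4 percentage points higher from compound 2 to compound 4 (beyond the scatter) and so shows that this position bears on the read-out, which the earlier compounds did not show through any single change. The step is large even though the trifluoromethyl group stays in place and the counts of hydrogen-bond donors and acceptors do not change. Nothing measured here bears on why the reading moves.

On these data alone, whether a carboxylic acid or a longer chain carrying the ester at this position would move the number further remains open. As far as these compounds go, it is also open whether the same exchange would have a similar effect on compound 1, which lacks the trifluoromethyl group.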